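This account rests on a few compounds, and the source may have more. Where it says the series, first, only, none or still open, it means among the compounds named here.

Three compounds share one core. Compound 1 `CC(C)=CCc1cc(C(=O)Nc2cc3ccc(OCCCN4CCCC4)c(C)c3oc2=O)ccc1O` and compound 2 `CCNCCCOc1ccc2cc(NC(=O)c3ccc(O)c(CC=C(C)C)c3)c(=O)oc2c1C` were measured in a functional assay on MCF7 cells (Homo sapiens) for antiproliferative activity; a higher number here means a weaker inhibitor, a lower number a stronger inhibitor: compound 1 gives 990 nM, and compound 2 gives 980 nM. Compound 3 `CCCN(CCC)CCCOc1ccc2cc(NC(=O)c3ccc(O)c(CC=C(C)C)c3)c(=O)oc2c1C` has no number in this assay, only a limit, > 50000 nM, sitting at the limit of > 50000 nM in this assay, at which 1 of the 3 values shown sits. Compound 4 `CC(C)=CCc1cc(C(=O)Nc2cc3ccc(OCCCNCC(N)=O)c(C)c3oc2=O)ccc1O` is not yet measured and differs from compound 3 by (carbamoylmethyl)amino in place of dipropylamino on a saturated chain carbon, three bonds along the chain from an oxygen on an aromatic ring. Within the data shown here, two measured steps bear on this change: an at least 50-fold higher number from compound 1 to compound 3 (1.70 log units; beyond the scatter) and an at least 51-fold higher number from compound 2 to compound 3 (1.70 log units; beyond the scatter), each moving toward dipropylamino. The change now under consideration moves away from dipropylamino toward a smaller secondary amine, so a large step toward a lower number in this assay is expected, an at least 25-fold lower number from compound 3 to compound 4 (1.39 log units; beyond the scatter). Compound 4 is therefore estimated at 2000 nM, with a range from 500 nM to 20000 nM.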

Compound 4, half-maximal inhibitory concentration: 1460 nM
Compound 4: middle estimate off by 1.4-fold (0.14 log units), on the high side; the range from low to high includes it.
By their numbers in this assay, from the lowest: compounds 2, 1 and 4 (each within the scatter of the next). At a limit, above all of these: compound 3.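

In this assay, (carbamoylmethyl)amino restores what dipropylamino loses, with an at least 34-fold lower number from compound 3 to compound 4 (1.53 log units; beyond the scatter). That step has no fixed size, as compound 3 has only a limit: the limit of > 50000 nM in this assay, at which 1 of the 4 values shown sits.

The new group also matches the earlier amines, with a 1.5-fold higher number from compound 2 to compound 4 (0.17 log units; within the scatter) and a 1.5-fold higher number from compound 1 to compound 4 (0.17 log units; within the scatter), so among the four compounds shown, only dipropylamino stands apart at this position.

Going by these compounds, whether the loss belongs to the propyl chains or to open-chain tertiary amines in general remains open, and dimethylamino or diethylamino on the same propyl chain would separate the two. On these data alone, the effect of a carboxylic acid in place of the carbamoyl also remains open.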